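The source may hold more compounds than are shown below. What is called first, only, known or untested is meant among the compounds shown, and "the series" means these compounds.

Compound 1 `O=C1NCCN1c1ccc(S(=O)(=O)Nc2ccc3[nH]ccc3c2)cc1`: 87 nM
Compound 2 `CCc1ccc(NS(=O)(=O)c2ccc(N3CCNC3=O)cc2)cc1`: 480 nM

Going by the values given here, in a functional assay on M21 cells (Homo sapiens) for antiproliferative activity, read by sulforhodamine B assay, with a stated time of 48 h (on this read-out higher numbers stand for weaker inhibition and lower numbers for stronger inhibition), compound 2 gives the higher of the two numbers measured so far, and its nearest neighbour, compound 1, sits clearly beyond the scatter on the stronger side. Compound 3 `O=C1NCCN1c1ccc(S(=O)(=O)Nc2ccc(Br)cc2)cc1` has not yet been measured. It differs from compound 2 in one place: bromo in place of ethyl on an aromatic carbon. Among the compounds with values here, no measured pair shows this same change, so nothing directly anchors it. The step from compound 2 to compound 3 is expected to be a 1.2-fold lower number from compound 2 to compound 3 (0.08 log units; within the scatter), none beyond the scatter. Compound 3 is estimated at 400 nM, with a range from 120 nM to 1500 nM.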

Compound 3, half-maximal inhibitory concentration: 130 nM
Beside the measured number, compound 3's estimate is 3.1-fold (0.49 log units) above it; the measured number falls inside the stated range.
By their numbers in this assay, from the lowest: compounds 1 and 3 (each within the scatter of the next); then compound 2.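

The aromatic carbon para to a large group is sensitive to what it carries: in this assay the change from 4-ethylphenyl to 4-bromophenyl gives a 3.7-fold lower number from compound 2 to compound 3 (0.57 log units; beyond the scatter) even though neither group has hydrogen-bond donors or acceptors. This is still a single pair, so it shows one swap and not a trend.

Going by these compounds, whether an amine, a methoxy group or a carboxylic acid at this carbon would keep or lose the gain stays open. No measurement shown explains the step.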